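The compounds below may be only part of what the source reports. "The series", "measured", "known", "first", "only" and "open" are said of these compounds alone.

Compound 1 `COC(=O)C1=C(C)NC(=S)NC1c1ccoc1` and compound 2 `CCCOC(=O)C1=C(C)NC(=S)NC1c1ccoc1` share one core. In an assay on membranes from HEK293 cells for displacement of a labelled ligand from adenosine receptor A2b (Homo sapiens), read by scintillation counting, with a stated time of 30 min, tested at 1 uM (on this read-out higher numbers stand for more inhibition at the one concentration tested (going by the name of the read-out) and lower numbers for less inhibition), compound 1 gives 48% and compound 2 gives 45%. The change between them is ethyl in place of hydrogen on a saturated chain carbon bound to an oxygen next to a carbonyl group, and it made a step of a number 3 percentage points lower from compound 1 to compound 2 (within the scatter). Compound 3 `COC(=O)C1=C(C)N(C)C(=O)NC1c1ccco1` is built on another core; the difference between the two cores is not broken down here. In this assay compound 3 gives 31%, lower than compound 2 and compound 1 by gaps beyond the scatter. Compound 4 `CCCOC(=O)C1=C(C)N(C)C(=O)NC1c1ccco1` carries the same change on the core of compound 3: ethyl in place of hydrogen on a saturated chain carbon bound to an oxygen next to a carbonyl group. The place of the change reads the same in both pairs, so this is the same change. For compound 4 the expected step is a number 2 percentage points lower from compound 3 to compound 4 (within the scatter), which rests on the earlier step being a number 3 percentage points lower from compound 1 to compound 2 (within the scatter). Compound 4 is therefore expected to give about 29% in this assay, with a likely range from 16% to 42%.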

Compound 4, a percentage reported as inhibition, at one concentration (the size of the read-out at that concentration, not a potency): 23%
For compound 4 the middle estimate is 6 percentage points above the measured one; the range from low to high includes it.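

In this assay the change from methoxycarbonyl to propoxycarbonyl gives a number 8 percentage points lower from compound 3 to compound 4 (within the scatter), and the two cores do not separate on this change: the same change on two cores in this assay, a number 3 percentage points lower (within the scatter) from compound 1 to compound 2 and a number 8 percentage points lower (within the scatter) from compound 3 to compound 4, 5 percentage points apart, within the scatter of two such steps

Carrying the change from the core of compound 1 to the core of compound 3 therefore holds for these two pairs, but neither step lies beyond the scatter, so neither pair shows that the change alters the read-out. Two pairs tested at one concentration give no potency and do not show how the change behaves on any other core.

Open, as far as these compounds go, is whether a chain longer than propoxy, or a carboxylic acid in place of propoxycarbonyl, would give a step beyond the scatter. From the compounds shown here alone, the contribution of each structural difference between the two cores also remains open.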